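A few compounds are considered here, and "the series" means these few. Any claim that something is new, unique, unknown or untested is made for them only; others in the source may bear on it.

In a functional assay on the whole organism (strain Albino Swiss CD1) with Mus musculus as the target, in the maximal electroshock model (on this read-out lower numbers stand for an effect already at smaller amounts and higher numbers for an effect only at larger amounts of compound), compound 1 `CCC(C(=O)NCc1ccccc1)N1C(=O)CCC1=O` gives 73.3 mg/kg. Compound 2 `CCC(C(=O)NCc1ccc(Cl)cc1)N1C(=O)CCC1=O` carries a chloro group on the aromatic ring, and in this assay compound 2 gives 95.4 mg/kg. The step of a 1.3-fold higher number from compound 1 to compound 2 (0.11 log units; within the scatter) is the only measured one, and it stays within the scatter. Among the two numbers in this assay, compound 2 has the higher one, with compound 1 its nearest neighbour and the gap between them within the scatter.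

Compound 3 `CCC(C(=O)NCc1ccc(C(F)(F)F)cc1)N1C(=O)CCC1=O` has not yet been measured in this assay. It differs from compound 2 by trifluoromethyl in place of chloro on an aromatic carbon. Within the data shown here, the one measured step that bears on this position, the one from compound 1 to compound 2, was small and within the scatter, so there is no sign in the numbers that a change at this aromatic carbon moves the read-out much. On that ground compound 3 is expected to give about 100 mg/kg in this assay, between 50 mg/kg and 200 mg/kg. The step this estimate implies, a 1.0-fold higher number from compound 2 to compound 3 (0.02 log units; within the scatter), is expected to be no larger than the scatter.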

Compound 3, dose for half-maximal effect: 69.4 mg/kg
Estimate against measurement, compound 3: 1.4-fold (0.16 log units) above; measured number inside the range.
By their numbers in this assay, from the lowest: compounds 3, 1 and 2 (each within the scatter of the next).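

In this assay, the exchange of chloro for trifluoromethyl gives a 1.4-fold lower number from compound 2 to compound 3 (0.14 log units; within the scatter), and trifluoromethyl in place of hydrogen gives a 1.1-fold lower number from compound 1 to compound 3 (0.02 log units; within the scatter). Among these compounds, this aromatic carbon, para to a large group, has now carried hydrogen, chloro and trifluoromethyl, and the read-out does not separate the three, even though trifluoromethyl brings 4 heavy atoms where chloro brings 1; the single earlier step could not show that a larger group also leaves the number within the scatter. Nothing available here explains why these changes leave the read-out so little moved.

As far as these compounds go, all three substituents carry no hydrogen-bond donors, no hydrogen-bond acceptors and no net charge, so it remains open whether the read-out would stay as flat with an amine or a carboxylic acid on this carbon. All three compounds also keep the rest of the shared core unchanged, which leaves open whether a longer chain in place of the one on that core would shift the number by more than the scatter.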